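Swapping a ring for a short chain on a lactam carbamate

The source may report more compounds than this note shows. Statements on the series, on what has been measured and on what is new or still open speak of the compounds shown alone.

Measured compounds:
compound 1 `O=C(N[C@H]1CNC1=O)OCc1ccc(C2CCOCC2)cc1` — 1370 nM
compound 2 `O=C(N[C@H]1CNC1=O)OCCCCc1ccccn1` — 30700 nM

In an assay on HEK293 cells for inhibition of N-acylethanolamine-hydrolyzing acid amidase (Homo sapiens), read by fluorescence, with stated times of 10 min and 50 min (on this read-out higher numbers stand for weaker inhibition and lower numbers for stronger inhibition), compound 1 gives 1370 nM, the lowest of the two numbers; compound 2 gives 30700 nM, a gap well beyond the scatter. Compound 3 `CCc1ccc(COC(=O)N[C@H]2CNC2=O)cc1` keeps the core of compound 1 and differs by one change: ethyl in place of oxan-4-yl on an aromatic carbon. Among the measured compounds shown here, no measured pair shows this kind of exchange, so the expectation rests on compound 1 alone. The estimated step of a 1.6-fold higher number from compound 1 to compound 3 (0.21 log units; within the scatter) is a modest weakening, not clearly beyond the scatter. Compound 3 is therefore expected at about 2200 nM, with a range from 600 nM to 8000 nM.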

Compound 3, half-maximal inhibitory concentration: 160 nM
The estimate for compound 3 lay 14-fold (1.14 log units) above the measured number; measured number outside the range, below it.
By their numbers in this assay, from the lowest: compound 3; then compound 1; then compound 2.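

In this assay, placing ethyl in place of oxan-4-yl on this aromatic carbon gives an 8.6-fold lower number from compound 1 to compound 3 (0.93 log units; beyond the scatter). The ring and its hydrogen-bond acceptor are therefore not needed for inhibition at this position, and a group of 2 heavy atoms does better here than one of 6. No available evidence bears on why the number falls.

This single exchange cannot separate the loss of the ring from the loss of its oxygen. From the compounds shown here alone, how methyl, a longer chain such as butyl, or an amine would fare at this position stays open.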